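This account rests on a few compounds, and the source may have more. Where it says the series, first, only, none or still open, it means among the compounds named here.

Measured so far:
compound 1 `O=C(Nc1cccc(Oc2nccc(C(F)(F)F)c2Cl)c1)C1CCCN(C(=O)c2cc(C(F)(F)F)cc(C(F)(F)F)c2)C1` — 0%
compound 2 `CCc1cccc(NC(=O)C2CCCN(C(=O)c3cc(C(F)(F)F)cc(C(F)(F)F)c3)C2)c1` — 0%

In an ADME assay on PC-3 cells (Homo sapiens) for cytotoxicity, read by WST assay, tested at 100 uM (on this read-out higher numbers stand for more inhibition at the one concentration tested (going by the name of the read-out) and lower numbers for less inhibition), compound 1 gives 0%. Compound 2 gives 0% in this assay, so compound 1 stands level with compound 2 at the digits shown; neither compound reaches any inhibition beyond the scatter at the single concentration tested. For the measured compounds named here, the only measured step, no change at the digits printed from compound 1 to compound 2 (within the scatter), is the replacement of the (3-chloro-4-(trifluoromethyl)pyridin-2-yl)oxy group by ethyl on an aromatic carbon, and it left the read-out unchanged.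

Compound 3 `O=C(Nc1cccc(Cc2ccccc2)c1)C1CCCN(C(=O)c2cc(C(F)(F)F)cc(C(F)(F)F)c2)C1` has not yet been measured in this assay. Its difference from compound 1 is benzyl in place of (3-chloro-4-(trifluoromethyl)pyridin-2-yl)oxy on an aromatic carbon. The group that leaves is the same as in the measured step; what enters is benzyl rather than ethyl, so the measured step bears on this one directly but not exactly. Since that step was flat, and both measured compounds sit at the floor of the read-out, no step beyond the scatter is expected in this assay.

Compound 3 is therefore expected to give 0% (range 0% to 12%), corresponding to an expected step of no change at the digits printed from compound 1 to compound 3 (within the scatter).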

Compound 3, a percentage reported as inhibition, at one concentration (the size of the read-out at that concentration, not a potency): 0%
The estimate for compound 3 equals the measured number at the digits printed; low and high end bracket the measured number.
By their numbers in this assay, from the lowest: compounds 1, 2 and 3 (each within the scatter of the next).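

Benzyl is a second replacement for the (3-chloro-4-(trifluoromethyl)pyridin-2-yl)oxy group on an aromatic carbon, meta to a large group, and in this assay the result is no change at the digits printed from compound 1 to compound 3 (within the scatter), so the flat outcome no longer rests on ethyl alone and holds for an entering group with a six-membered aromatic ring of carbon only. Within this smaller pair, phenyl in place of methyl on the saturated chain carbon bound to the aromatic carbon gives no change at the digits printed from compound 2 to compound 3 (within the scatter), which shows that adding this ring to the ethyl group does not move the read-out off the level shared by all three compounds. No measurement at hand gives a cause for this flat read-out.

With all three compounds level in this assay at a single concentration, the series gives no step beyond the scatter and no order among these groups at this position. From the compounds shown here alone, whether an amine, a carboxylic acid or a longer chain at the same aromatic carbon would depart from this level stays open, as does any effect of changing the rest of the core, which is the same in all three compounds.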